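This account rests on a few compounds, and the source may have more. Where it says the series, first, only, none or still open, it means among the compounds named here.

Compound 3 `Cc1ccc(NC(=O)Nc2cc(C)nc3ccccc23)cc1` links the shared core, through an amide-type nitrogen and a carbonyl carbon, to a 4-methylphenyl group. In an ADME assay on Raji cells (Homo sapiens) for cytotoxicity, with a stated time of 72 h (on this read-out higher numbers stand for an effect only at larger amounts of compound and lower numbers for an effect already at smaller amounts), compound 3 gives > 25000 nM, which is a limit of the assay rather than a number. Two close relatives differ from compound 3 in a single place. Compound 1 `COc1ccc(NC(=O)Nc2cc(C)nc3ccccc23)cc1` carries methoxy where compound 3 carries methyl on an aromatic carbon. In this assay compound 1 gives > 25000 nM, again a limit. Compound 2 `Cc1cc(NC(=O)Nc2ncccc2C)c2ccccc2n1` carries 3-methylpyridin-2-yl on the amide-type nitrogen. In this assay compound 2 gives > 25000 nM, also a limit. The two steps, a step that the two limits leave unreadable from compound 1 to compound 3 and a step that the two limits leave unreadable from compound 2 to compound 3, cannot be sized because of the limit of > 25000 nM in this assay, at which 3 of the 3 values shown sit. Compound 4 `Cc1cc(NC(=O)Nc2ccccc2F)c2ccccc2n1` has not yet been measured. It differs from compound 3 as follows: 2-fluorophenyl in place of 4-methylphenyl on an amide-type nitrogen. Among the measured compounds shown here, no measured step covers this exchange of 2-fluorophenyl for 4-methylphenyl, and the steps that exist are unreadable, so no direction beyond the scatter can be expected. The step that this estimate means, a step that the limit leaves unreadable from compound 3 to compound 4, is expected to be small. Compound 4 is therefore expected to give about 40000 nM in this assay, within a range from 15000 nM to 120000 nM, most probably reported once more only as a limit.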

Compound 4, half-maximal effective concentration: > 25000 nM
Compound 4 gave a limit, no number (the forecaster's own chance of this, stated with the estimate: 80%); the middle value does not contradict the limit.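

Compound 4, like compound 2 and compound 3, gives a limit of the assay rather than a number, so neither step to compound 4 can be read: the limit of > 25000 nM in this assay, at which 4 of the 4 values shown sit. The compounds shown leave open how large any of these exchanges really is in this assay, and at what amount of compound an effect would appear.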